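Fluoro to trifluoromethyl on the aryloxy ring of the series

The compounds below may be only part of what the source reports. "The series", "measured", "known", "first", "only" and "open" are said of these compounds alone.

Measured so far:
compound 1, `CN(Cc1ccc(OCCCNC(=N)N)cc1)c1nc2ccc(Oc3ccc(C(F)(F)F)cc3)cc2s1`, 185000 nM
compound 2, `N=C(N)NCCCOc1ccc(CNc2nc3ccc(Oc4ccc(F)cc4)cc3s2)cc1`, 244000 nM

Both compounds were read in an assay on SH-SY5Y cells for inhibition of Voltage-dependent N-type calcium channel subunit alpha-1B (Homo sapiens), read by FLIPR and calcium flux, with stated times of 600 s and 300 s, in the presence of a further agent that is not named here; on this read-out higher numbers stand for weaker inhibition and lower numbers for stronger inhibition. Compound 2 gives the higher of the two numbers, 244000 nM, but the gap to compound 1 with 185000 nM is within the scatter of the assay, so the two compounds cannot be ordered against each other on this read-out. Both numbers sit far up the concentration scale.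

Compound 3, `N=C(N)NCCCOc1ccc(CNc2nc3ccc(Oc4ccc(C(F)(F)F)cc4)cc3s2)cc1`, is not yet measured. Its change from compound 2 is trifluoromethyl in place of fluoro on an aromatic carbon, para to a large group. Among the measured compounds shown here, compound 1 already carries the trifluoromethyl group, though with a further difference at the nitrogen, and its value does not stand apart from that of compound 2; no step between compounds that differ only in this one place is known.

The step of a 1.2-fold lower number from compound 2 to compound 3 (0.07 log units; within the scatter) is therefore expected to stay within the scatter, with no clear direction. Compound 3 is expected to give about 210000 nM, with a range from 100000 nM to 450000 nM.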

Compound 3, half-maximal inhibitory concentration: 167000 nM
Compound 3: middle estimate off by 1.3-fold (0.10 log units), on the high side; measured number inside the range.
By their numbers in this assay, from the lowest: compounds 3, 1 and 2 (each within the scatter of the next).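

In this assay, the step at this position, a 1.5-fold lower number from compound 2 to compound 3 (0.16 log units; within the scatter), shows that trifluoromethyl in place of fluoro on an aromatic carbon, para to a large group, does not separate the two compounds, which the earlier pair, differing in two places, could not show. The second single-place step, a 1.1-fold lower number from compound 1 to compound 3 (0.04 log units; within the scatter), shows the same for hydrogen in place of methyl on a nitrogen on an aromatic ring, so neither change moves the number beyond the scatter, and all of these numbers remain far up the concentration scale. No measurement is available that could explain either result.

Still open, as far as these compounds go, is whether a group of another kind on the same aromatic carbon, such as a carboxylic acid or an amine, would give a number beyond the scatter of compound 3. Among the compounds shown here, also open is whether a change elsewhere in compound 3, such as a longer chain in place of the one carrying the guanidine group, would bring the number down from this high region of the scale.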